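Chloro on the pyridine ring: a second core tested

A few compounds are considered here, and "the series" means these few. Any claim that something is new, unique, unknown or untested is made for them only; others in the source may bear on it.

Compound 1 `COc1ccccc1S(=O)(=O)/C=C/c1ccccn1` is the reference point of this small set. In an ADME assay on BV-2 cells (Mus musculus) for cytotoxicity, with a stated time of 24 h, tested at 50 uM (a higher number here means a weaker effect of the compound at the concentration tested, a lower number a stronger effect), compound 1 gives 100%. Compound 2 `COc1ccccc1S(=O)(=O)/C=C/c1cccc(Cl)n1` carries one change against compound 1, (chloro in place of hydrogen on an aromatic carbon), and in this assay compound 2 gives 80.5%. For the measured compounds named here, the step of a number 19.5 percentage points lower from compound 1 to compound 2 (beyond the scatter) is the only measured step in the set.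

Compound 3 `COc1ccc(S(=O)(=O)/C=C/c2ccccn2)cc1` has the same atoms as compound 1 joined differently; the difference between the two cores is not broken down here. In this assay compound 3 gives 100%, which stands level with compound 1 at the digits reported and is the furthest from compound 2.

Compound 4 `COc1ccc(S(=O)(=O)/C=C/c2ccc(Cl)cn2)cc1` is to be measured. Against compound 3 it differs by chloro in place of hydrogen on an aromatic carbon. Going by the values given here, this is the same kind of change as the one from compound 1 to compound 2, but not the same: there the chloro sits next to the ring nitrogen, meta to a large group, while here it sits two atoms from the ring nitrogen, para to a large group. Among the compounds with values here, because compound 3 sits at 100% and the only comparable step is a number 19.5 percentage points lower from compound 1 to compound 2 (beyond the scatter), the expected step from compound 3 to compound 4 is a number 15 percentage points lower from compound 3 to compound 4 (beyond the scatter), taken a little more cautiously than the measured one on account of the different place. Compound 4 is accordingly expected to give about 85%, with a plausible range from 65% to 100%.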

Compound 4, a percentage reported as activity, at one concentration (the size of the read-out at that concentration, not a potency): 84.1%
For compound 4 the middle estimate is 0.9 percentage points above the measured one; the range from low to high includes it.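

In this assay, chloro in place of hydrogen on an aromatic carbon again goes with a lower number, with a number 15.9 percentage points lower from compound 3 to compound 4 (beyond the scatter). Set beside the earlier step, the change carries from one core to the other at much the same size, although the chloro does not stand at the same place on the ring in the two pairs: the same change on two cores in this assay, a number 19.5 percentage points lower (beyond the scatter) from compound 1 to compound 2 and a number 15.9 percentage points lower (beyond the scatter) from compound 3 to compound 4, 3.6 percentage points apart, within the scatter of two such steps. This shows that two pairs agree in direction and in size in this one assay at a single concentration, but it does not separate the effect of the core from the effect of the chloro's place, and it says nothing about why the number falls or whether a step of this size would hold on any further core.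

Still open, from the compounds shown here alone, is whether chloro at one and the same place on both cores would give matching steps, and how the number would respond with chloro on the other ring of the shared skeleton. Also open, going by these compounds, is whether a different group in place of that hydrogen, such as an amine, a carboxylic acid or a longer chain, would move the number as chloro does.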